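Trimethoxyphenyl triazoles: a fluorophenyl in place of methylphenyl

The source may hold more compounds than are shown below. What is called first, only, known or untested is meant among the compounds shown, and "the series" means these compounds.

Going by the values given here, compound 1 `COc1cc(-n2ncnc2-c2ccc(C)cc2)cc(OC)c1OC` is the only compound in this set with a number in a functional assay on Jurkat cells (Homo sapiens) for antiproliferative activity, read by MTT assay, with a stated time of 72 h; a higher number here means a weaker inhibitor, a lower number a stronger inhibitor: compound 1 gives 300 nM. The two other measured compounds return only a limit. Compound 2 `COc1cc(-c2ncnn2-c2ccc(Cl)cc2Cl)cc(OC)c1OC` sits at the limit > 10000 nM in this assay. Compound 3 `COc1cc(-c2ncnn2-c2ccc([N+](=O)[O-])cc2)cc(OC)c1OC` likewise reaches only the limit > 10000 nM. Among the compounds with values here, both therefore stand at the limit of > 10000 nM in this assay, at which 2 of the 3 values shown sit, so compound 1 has the single value that can be carried forward, and no pair of measured compounds differs in just one place, leaving no measured step to lean on.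

Compound 4 `COc1cc(-n2ncnc2-c2cccc(F)c2)cc(OC)c1OC` has not been measured. It differs from compound 1 by 3-fluorophenyl in place of 4-methylphenyl on an aromatic carbon. With nothing in the measured set to anchor this change, the expectation rests on compound 1 at 300 nM alone, and a moderate loss beyond the scatter is expected rather than no change. Compound 4 is estimated at 1500 nM, with a range from 300 nM to 8000 nM. That estimate means an expected step of a 5.0-fold higher number from compound 1 to compound 4 (0.70 log units; beyond the scatter) in this assay.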

Compound 4, half-maximal inhibitory concentration: > 10000 nM
Compound 4 was reported as a limit (the forecaster's own chance of this, stated with the estimate: 20%); middle value at least 6.6-fold (0.82 log units) from the limit.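

On these data alone, at this aromatic carbon of the five-membered ring, 3-fluorophenyl in place of 4-methylphenyl gives an at least 33-fold higher number from compound 1 to compound 4 (1.52 log units; beyond the scatter) in this assay, so the step is large even though the exact size remains unknown. Compound 4 keeps the core of compound 1, which ties this loss to the aryl group alone, something compounds 2 and 3 could not show, as each differs from compound 1 in more than one place. Compound 4 is reported only as a limit, and it joins the other limit values: the limit of > 10000 nM in this assay, at which 3 of the 4 values shown sit.

The change alters both the substituent and where it sits on the phenyl ring, and the compounds shown do not separate the two. As far as these compounds go, how 4-fluorophenyl or 3-methylphenyl would read at this carbon stays open, as does the reading for 4-methoxyphenyl.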